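Hydrogen in Place of Chloro: What to Expect

The compounds below may be only part of what the source reports. "The series", "measured", "known", "first", "only" and "open" are said of these compounds alone.

compound 1 `CONC(=S)N/N=C1\C(=O)N(CN2CCN(c3ccc(Cl)cc3)CC2)c2ccc(C)cc21` gives 300000 nM
compound 2 `Cc1ccc2c(c1)/C(=N/NC(=S)NO)C(=O)N2CN1CCN(c2ccc(Cl)cc2)CC1` gives 335000 nM
compound 3 `CONC(=S)N/N=C1\C(=O)N(CN2CCN(c3ccc(Cl)cc3)CC2)c2ccc(F)cc21` gives 347000 nM

All three values come from an ADME assay on MT4 cells (Homo sapiens) for cytotoxicity, read by spectrophotometry, with a stated time of 5 days; on this read-out lower numbers stand for higher toxicity in this test and higher numbers for lower toxicity in this test. Compound 1 sits with the other two inside the usual scatter of repeated measurements, so no order among them can be read.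

Compound 4 `CONC(=S)N/N=C1\C(=O)N(CN2CCN(c3ccccc3)CC2)c2ccc(C)cc21` has not been measured yet. It differs from compound 1 in one place: hydrogen in place of chloro on an aromatic carbon. In words, this is hydrogen in place of chloro on an aromatic carbon, which turns 4-chlorophenyl into phenyl.

Among the measured compounds shown here, two measured steps bear on this change, though neither touches the chloro. The closer in kind is a 1.2-fold higher number from compound 1 to compound 3 (0.06 log units; within the scatter), which comes with fluoro in place of methyl on an aromatic carbon. The other is a 1.1-fold higher number from compound 1 to compound 2 (0.05 log units; within the scatter), which comes with hydrogen in place of methyl on an oxygen. Both lie within the scatter. For the measured compounds named here, no measured compound here lacks the chloro, so the evidence is only indirect. A step beyond the scatter in this assay is therefore not expected, and no direction can be called. The expected size of the change is a 1.1-fold higher number from compound 1 to compound 4 (0.03 log units; within the scatter). For compound 4 the estimated value is 325000 nM, with an expected range from 190000 nM to 520000 nM.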

Compound 4, half-maximal cytotoxic concentration: 276000 nM
Estimate against measurement, compound 4: 1.2-fold (0.07 log units) above, within the range that was stated.
By their numbers in this assay, from the lowest: compounds 4, 1, 2 and 3 (each within the scatter of the next).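

Among the compounds shown here, compound 4 is the first compound here in which the chloro itself is changed, so this position now has a direct reading, where the earlier steps, made elsewhere on the molecule, could offer only an indirect one. In this assay, for the compounds shown here, the change from 4-chlorophenyl to phenyl gives a 1.1-fold lower number from compound 1 to compound 4 (0.04 log units; within the scatter), so on the core of compound 1, this chlorine atom, para to a large group, can be replaced by hydrogen with no step that stands out from the ordinary spread of repeated measurements, and no direction can be called. No measurement shown here offers an explanation for this result.

On these data alone, what remains open is whether a different kind of group in place of the chloro, such as an amine, a carboxylic acid or a longer chain, would give a step beyond the scatter. This reading also rests on a single pair of compounds, so it cannot say whether the same swap would behave alike on the cores that carry a hydroxyl group on the side chain or a fluoro on the aromatic ring.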